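Swapping Chloro for Bromo in a Cytotoxicity Series

This account rests on a few compounds, and the source may have more. Where it says the series, first, only, none or still open, it means among the compounds named here.

Four closely related compounds share a core bearing two fluorophenyl arms and an aryl sulfonyl group. Compound 1 `O=C1/C(=C/c2ccccc2F)CN(S(=O)(=O)c2ccc(Cl)cc2)C/C1=C\c1ccccc1F` and compound 2 `O=C1/C(=C/c2ccccc2F)CN(S(=O)(=O)c2ccc(Br)cc2)C/C1=C\c1ccccc1F` carry the fluorine in one position of each arm; compound 3 `O=C1/C(=C/c2cccc(F)c2)CN(S(=O)(=O)c2ccc(Cl)cc2)C/C1=C\c1cccc(F)c1` and compound 4 `O=C1/C(=C/c2cccc(F)c2)CN(S(=O)(=O)c2ccc(Br)cc2)C/C1=C\c1cccc(F)c1` carry it in another. The difference between the two cores is not broken down here.

All were studied in an ADME assay on L02 cells (Homo sapiens) for cytotoxicity, read by MTT assay, with a stated time of 24 h; on this read-out lower numbers stand for stronger inhibition and higher numbers for weaker inhibition. Compound 1 gives 14100 nM, and compound 2 gives 16200 nM. The change between them, (bromo in place of chloro on an aromatic carbon), produced a 1.1-fold higher number from compound 1 to compound 2 (0.06 log units; within the scatter). Compound 3 gives 15700 nM; its number and those of compound 1 and compound 2 lie within the usual scatter of one another, so no order among them can be read.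

Compound 4 is not yet measured. It differs from compound 3 by bromo in place of chloro on an aromatic carbon, the same change already seen from compound 1 to compound 2, at the same place. Because a 1.1-fold higher number from compound 1 to compound 2 (0.06 log units; within the scatter) lies within the scatter, the expectation is that this second occurrence will behave alike. The expected step is a 1.1-fold higher number from compound 3 to compound 4 (0.05 log units; within the scatter), set beside the earlier one. Compound 4 is therefore expected to give about 17500 nM, with a likely range from 9000 nM to 35000 nM. This rests on one example only, so the range is kept wide.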

Compound 4, half-maximal inhibitory concentration: 15800 nM
Beside the measured number, compound 4's estimate is 1.1-fold (0.04 log units) above it; low and high end bracket the measured number.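

In this assay, the new step is a 1.0-fold higher number from compound 3 to compound 4 (0.00 log units; within the scatter), so on this core the swap of 4-chlorophenyl to 4-bromophenyl gives no change that can be read. Set beside the earlier step, the two cores give the same answer: the same change on two cores in this assay, a 1.1-fold higher number (0.06 log units; within the scatter) from compound 1 to compound 2 and a 1.0-fold higher number (0.00 log units; within the scatter) from compound 3 to compound 4, 1.1-fold (0.06 log units) apart, within the scatter of two such steps This shows that, across these two matched pairs, the swap carried from one core to the other without any readable difference in cytotoxicity on these cells, but it does not show that the two halogens are interchangeable in general, since two pairs are a small sample, a real difference smaller than the scatter would stay hidden, and a single read-out says nothing about other kinds of measurement.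

The compounds shown hold only chloro and bromo at this place on the ring, so it remains open whether a quite different group there, such as an amine, a carboxylic acid or a methoxy group, would move the number at all. From the compounds shown here alone, it also remains open whether the same swap would stay as quiet on a core whose arms carry something other than fluorine, such as a methyl group or a nitrile.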